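The source may report more compounds than this note shows. Statements on the series, on what has been measured and on what is new or still open speak of the compounds shown alone.

Measured compounds in a functional assay on RPMI8266 cells (Homo sapiens) for inhibition, read by sulforhodamine B assay, with a stated time of 48 h; on this read-out lower numbers stand for stronger inhibition of growth and higher numbers for weaker inhibition of growth:
- compound 1 `Nc1cc(N)c2nc(-c3ccccc3)c(NCc3ccc(Cl)c(Cl)c3)nc2c1` gives 1660 nM
- compound 2 `COc1ccc(CNc2nc3cc(N)cc(N)c3nc2-c2ccccc2)cc1OC` gives 2140 nM
- compound 3 `Nc1cc(N)c2nc(-c3ccccc3)c(NCc3ccc(F)cc3)nc2c1` gives 2510 nM

Compound 3 stands at the upper end of three numbers that cannot be told apart: a 1.2-fold higher number from compound 2 to compound 3 (0.07 log units; within the scatter) and a 1.5-fold higher number from compound 1 to compound 3 (0.18 log units; within the scatter). Compound 4 `COc1ccc(CNc2nc3cc(N)cc(N)c3nc2-c2ccccc2)cc1`, not yet measured, differs from compound 3 by methoxy in place of fluoro on an aromatic carbon.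

Bearing on this step are the three exchanges of the benzyl aryl substituent already in hand: a 1.3-fold higher number from compound 1 to compound 2 (0.11 log units; within the scatter), a 1.5-fold higher number from compound 1 to compound 3 (0.18 log units; within the scatter) and a 1.2-fold higher number from compound 2 to compound 3 (0.07 log units; within the scatter). Each of these swaps halogen for methoxy or halogen for halogen on the same ring, and none moved the growth inhibition beyond the scatter. The closest analogue to the present change, methoxy for chloro on the same positions, is a 1.3-fold higher number from compound 1 to compound 2 (0.11 log units; within the scatter). No step beyond the scatter in this assay is therefore expected in either direction.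

Compound 4 is estimated at 2300 nM, with a range from 1100 nM to 4800 nM. The step this estimate implies, a 1.1-fold lower number from compound 3 to compound 4 (0.04 log units; within the scatter), is expected to sit within the scatter.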

Compound 4, concentration for 50% growth inhibition: 4170 nM
Compound 4: middle estimate off by 1.8-fold (0.26 log units), on the low side; the range from low to high includes it.
By their numbers in this assay, from the lowest: compounds 1, 2, 3 and 4 (each within the scatter of the next, the first and the last beyond it).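

In this assay, methoxy in place of fluoro on the aromatic carbon para to a large group gives a 1.7-fold higher number from compound 3 to compound 4 (0.22 log units; within the scatter), so this exchange also stays within the scatter. Hydrogen in place of methoxy, which leads from 3,4-dimethoxyphenyl to 4-methoxyphenyl, gives a 1.9-fold higher number from compound 2 to compound 4 (0.29 log units; within the scatter), likewise within the scatter. The new point is that 4-methoxyphenyl in place of 3,4-dichlorophenyl gives a 2.5-fold higher number from compound 1 to compound 4 (0.40 log units; beyond the scatter), a modest step and the only one in this set beyond the scatter, so changes on this ring can be resolved only across the full span of the four compounds.

No evidence on the cause of that step is at hand. From the compounds shown here alone, whether an amine or a carboxylic acid in place of methoxy, or a longer chain in place of the benzyl carbon, would give a step beyond the scatter from compound 4 stays open.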